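The source may report more compounds than this note shows. Statements on the series, on what has been measured and on what is new or still open speak of the compounds shown alone.

Measured in a functional assay on EL4 cells (Mus musculus) for inhibition, tested at 100 uM; on this read-out lower numbers stand for less inhibition and higher numbers for more inhibition at the one concentration tested (going by the name of the read-out):
compound 1, `OC[C@H]1OC(n2cnc3c(Nc4ccccc4)nccc32)[C@H](O)[C@@H]1O`: 10%
compound 2, `OC[C@H]1OC(n2cnc3c(Cl)nccc32)[C@H](O)[C@@H]1O`: < 5%, which is a limit of the assay and not a number
compound 3, `OCCNc1nccc2c1ncn2C1O[C@H](CO)[C@@H](O)[C@H]1O`: 6%

Compound 3 holds the lowest of the two numbers; the nearest is compound 1, and the step of a number 4 percentage points lower from compound 1 to compound 3 (within the scatter) lies within the scatter, as does a number at least 1 percentage points higher from compound 2 to compound 3 (that floor lies within the scatter). The third value is a limit, and a number at least 5 percentage points lower from compound 1 to compound 2 (that floor lies within the scatter) is likewise within the scatter, so the three measured compounds are not separated from one another in this assay.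

Compound 4, `CCCCCCNc1nccc2c1ncn2C1O[C@H](CO)[C@@H](O)[C@H]1O`, differs from compound 3 by butyl in place of hydroxy on a saturated chain carbon, two bonds along the chain from a nitrogen on an aromatic ring. Going by the values given here, no measured step alters this part of the chain; the steps that touch the same side chain, a number 4 percentage points lower from compound 1 to compound 3 (within the scatter) and a number at least 1 percentage points higher from compound 2 to compound 3 (that floor lies within the scatter), were both within the scatter, and no measured step anywhere in the set goes beyond it. The expectation for compound 4 in this assay is therefore a step of a number 2 percentage points higher from compound 3 to compound 4 (within the scatter), none beyond the scatter. Compound 4 is estimated at 8%, between 2% and 20%. Because one value already sits at the limit of < 5% in this assay, at which 1 of the 3 values shown sits, a reported limit rather than a number is also possible for compound 4.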

Compound 4, a percentage reported as inhibition, at one concentration (the size of the read-out at that concentration, not a potency): 14%
Estimate against measurement, compound 4: 6 percentage points below; the range from low to high includes it.
By their numbers in this assay, from the lowest: compounds 3, 1 and 4 (each within the scatter of the next). At a limit, below all of these: compound 2.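

In this assay, going by these compounds alone, the change on a saturated chain carbon, two bonds along the chain from a nitrogen on an aromatic ring, is now covered for the first time, and butyl in place of hydroxy stays within the scatter (a number 8 percentage points higher from compound 3 to compound 4 (within the scatter)). Hexyl in place of phenyl on the nitrogen (a number 4 percentage points higher from compound 1 to compound 4 (within the scatter)) and hexylamino in place of chloro (a number at least 9 percentage points higher from compound 2 to compound 4 (that floor lies within the scatter)) also stay within it, so a hexyl chain does not separate compound 4 from the other compounds. Within the data shown here, compound 2 remains the one compound reported as a limit and not a number: the limit of < 5% in this assay, at which 1 of the 4 values shown sits.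

From the compounds shown here alone, whether an octyl or longer chain, or an amine or carboxylic acid at the end of the chain, would give a step beyond the scatter remains open. The single tested concentration also leaves the potency of every compound open.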